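The source may hold more compounds than are shown below. What is called first, only, known or untested is meant among the compounds shown, and "the series" means these compounds.

Compound 1, `O=[N+]([O-])c1ccc(CN2CCC(n3cc(CC(OCc4cc(-c5ccc(F)cc5)no4)c4ccc(Br)cc4)nn3)CC2)cc1`, gives in a functional assay on MCF7 cells (Homo sapiens) for cytotoxicity, with a stated time of 48 h (a lower number here means a stronger inhibitor, a higher number a weaker inhibitor), a value of 7000 nM. Compound 2, `COc1ccc(-c2cc(COC(Cc3cn(C4CCN(Cc5ccc([N+](=O)[O-])cc5)CC4)nn3)c3ccc(Br)cc3)on2)cc1`, carries the change methoxy in place of fluoro on an aromatic carbon on the core of compound 1; in this assay compound 2 gives 4000 nM, and the step is a 1.8-fold lower number from compound 1 to compound 2 (0.24 log units; within the scatter). Compound 3, `O=[N+]([O-])c1ccc(CN2CCC(n3cc(CC(OCc4cc(-c5ccccc5F)no4)c4ccc(Br)cc4)nn3)CC2)cc1`, is related to compound 1 by 2-fluorophenyl in place of 4-fluorophenyl on an aromatic carbon; in this assay compound 3 gives 8000 nM, so that a 1.1-fold higher number from compound 1 to compound 3 (0.06 log units; within the scatter) and a 2.0-fold higher number from compound 2 to compound 3 (0.30 log units; within the scatter). All three numbers sit within the scatter of one another, and no ordering among them is claimed.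

Compound 4, `COc1ccccc1-c1cc(COC(Cc2cn(C3CCN(Cc4ccc([N+](=O)[O-])cc4)CC3)nn2)c2ccc(Br)cc2)on1`, is not yet measured. It differs from compound 3 by methoxy in place of fluoro on an aromatic carbon. This is the same kind of change as that from compound 1 to compound 2, though not the same: there the entering group stands para to a large group, here ortho to a large group, and the two cores differ as told above. Going by the values given here, with only the one precedent, the step from compound 3 to compound 4 in this assay is expected to be about a 1.8-fold lower number from compound 3 to compound 4 (0.25 log units; within the scatter), resting on a 1.8-fold lower number from compound 1 to compound 2 (0.24 log units; within the scatter) and on compound 3 standing at 8000 nM. Compound 4 is thus estimated at 4500 nM, between 2000 nM and 12000 nM.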

Compound 4, half-maximal inhibitory concentration: 3000 nM
For compound 4 the middle estimate is 1.5-fold (0.18 log units) above the measured one; measured number inside the range.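

Methoxy in place of fluoro on an aromatic carbon lowers the number on both cores in this assay, and the two steps cannot be told apart in size: the same change on two cores in this assay, a 1.8-fold lower number (0.24 log units; within the scatter) from compound 1 to compound 2 and a 2.7-fold lower number (0.43 log units; beyond the scatter) from compound 3 to compound 4, 1.5-fold (0.18 log units) apart, within the scatter of two such steps. The swap of 2-methoxyphenyl for 4-methoxyphenyl gives a 1.3-fold lower number from compound 2 to compound 4 (0.12 log units; within the scatter), so that these two groups are not separated here, whereas 2-methoxyphenyl in place of 4-fluorophenyl gives a 2.3-fold lower number from compound 1 to compound 4 (0.37 log units; beyond the scatter), a modest step, as is a 2.7-fold lower number from compound 3 to compound 4 (0.43 log units; beyond the scatter). Going by these compounds alone, this shows that the change kept its direction on two closely related cores, with only one of the two steps beyond the scatter; it does not show a rule for the series, nor why the numbers move.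

Open, as far as these compounds go, is how a hydroxyl, an amine or a nitrile would read in place of methoxy on the same phenyl ring. Also open, from the compounds shown here alone, is whether the step holds once the bromine or the nitro group of the shared core is replaced, for instance by a chlorine or a carboxylic acid.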